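Swapping Fluorophenyl for Cyanophenyl on an Aromatic Nitrogen

The source may report more compounds than this note shows. Statements on the series, on what has been measured and on what is new or still open speak of the compounds shown alone.

Three compounds have been measured in an assay on a cell-free system (plasma) for inhibition of Dipeptidyl peptidase 4 (Rattus norvegicus), read by fluorescence, with a stated time of 60 min; on this read-out higher numbers stand for weaker inhibition and lower numbers for stronger inhibition:

compound 1 `O=C([C@@H]1C[C@H](N2CCN(c3nccn3-c3ccccc3)CC2)CN1)N1CCSC1` gives 0.19 nM
compound 2 `O=C([C@@H]1C[C@H](N2CCN(c3nc(-c4ccccc4)cs3)CC2)CN1)N1CCSC1` gives 5.4 nM
compound 3 `Cc1cc(N2CCN([C@@H]3CN[C@H](C(=O)N4CCSC4)C3)CC2)n(-c2cccc(F)c2)n1` gives 0.49 nM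

In this assay a lower number stands for stronger inhibition. Compound 3 holds the second highest of the three numbers. Its nearest neighbour is compound 1, whose number is lower by a gap beyond the usual scatter; its furthest is compound 2, whose number is higher by a much wider gap, also beyond the scatter.

Compound 4 `Cc1cc(N2CCN([C@@H]3CN[C@H](C(=O)N4CCSC4)C3)CC2)n(-c2ccc(C#N)cc2)n1` has not yet been measured. It differs from compound 3 in one place: 4-cyanophenyl in place of 3-fluorophenyl on an aromatic nitrogen. For the measured compounds named here, no pair of measured compounds shows this change, so no measured step speaks to it directly, and all that can be leaned on is the value of compound 3 itself. With nothing pointing either way, the expected step is a 1.2-fold higher number from compound 3 to compound 4 (0.09 log units; within the scatter), that is, no shift beyond the usual scatter in this assay. Compound 4 is therefore estimated at 0.6 nM, with a range from 0.2 nM to 2 nM.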

Compound 4, half-maximal inhibitory concentration: 13 nM
Estimate against measurement, compound 4: 22-fold (1.34 log units) below, and the stated range ends below it.
By their numbers in this assay, from the lowest: compound 1; then compound 3; then compound 2; then compound 4.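

In this assay the step of a 27-fold higher number from compound 3 to compound 4 (1.42 log units; beyond the scatter) shows that this position is far from indifferent: 4-cyanophenyl in place of 3-fluorophenyl on the aromatic nitrogen brings much weaker inhibition. For the compounds shown here, until now compound 3 alone represented this position, so the earlier compounds gave no sign that a change confined to the phenyl group could matter this much. Nothing measured here offers an explanation for the size of this loss.

The change replaces the fluorine with a nitrile and shifts the substituent's place on the phenyl ring in a single step, and the compounds shown cannot separate these two differences. A 3-cyanophenyl or 4-fluorophenyl group on this nitrogen would pull them apart, while a 4-aminophenyl group would show how a different substituent fares at that place on the ring.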